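The compounds below may be only part of what the source reports. "The series", "measured", "known", "first", "only" and "open" are said of these compounds alone.

Measured compounds in this series:
compound 1 `Nc1scc(-c2ccc(F)cc2)c1C(=O)c1ccccc1` — 60%
compound 2 `Nc1scc(-c2ccc(Cl)cc2)c1C(=O)c1ccccc1` — 51%
compound 3 `Nc1scc(-c2ccc(F)cc2)c1C(=O)c1ccc(Cl)cc1` — 61%

In a functional assay on CHO cells for agonist activity at adenosine receptor A1 (Homo sapiens), read by fluorescence and ERK phosphorylation, with stated times of 30 min and 1.5 h, tested at 10 uM (a lower number here means a weaker effect, a higher number a stronger effect of the compound at the concentration tested), compound 3 gives the nominally largest figure, yet the set does not spread beyond the scatter: the step of a number 1 percentage points higher from compound 1 to compound 3 (within the scatter) is within it, and the values of compound 2 and compound 3 also lie within the scatter of each other. Compound 4 `Nc1scc(-c2ccc(Br)cc2)c1C(=O)c1ccc(Cl)cc1` differs from compound 3 by bromo in place of fluoro on an aromatic carbon. Within the data shown here, the one measured step that bears on this is the exchange of one halogen for another on an aromatic carbon, a number 9 percentage points lower from compound 1 to compound 2 (within the scatter), which stayed within the scatter. No larger shift is therefore expected for compound 4, the estimated step being a number 4 percentage points lower from compound 3 to compound 4 (within the scatter). Compound 4 is accordingly estimated at 57%, in the range 42% to 72%.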

Compound 4, a percentage reported as activity, at one concentration (the size of the read-out at that concentration, not a potency): 46%
The estimate for compound 4 lay 11 percentage points above the measured number; low and high end bracket the measured number.
By their numbers in this assay, from the lowest: compounds 4, 2, 1 and 3 (each within the scatter of the next, the first and the last beyond it).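

In this assay, the change from 4-fluorophenyl to 4-bromophenyl gives a number 15 percentage points lower from compound 3 to compound 4 (beyond the scatter), so a halogen exchange on this aromatic carbon, para to a large group, can move the read-out beyond the scatter. The earlier exchange of fluoro for chloro gave only a number 9 percentage points lower from compound 1 to compound 2 (within the scatter), which stayed within it. Nothing at hand accounts for the loss seen with bromo.

Open, from the compounds shown here alone, is whether bromo gives a similar step on the core of compound 1. Also open, going by these compounds, is how a methoxy group, an amine or a carboxylic acid at this position would read.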